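A Chloro Substituent Enters a Urea Analogue

The source may hold more compounds than are shown below. What is called first, only, known or untested is meant among the compounds shown, and "the series" means these compounds.

Compound 3 `CC1(C)CC(NC(=O)Nc2ccccc2)c2cc(Cl)ccc2O1` carries a urea linker, and in a functional assay on B16-F10 cells (Mus musculus) for inhibition, read by MTT assay, with a stated time of 72 h (on this read-out higher numbers stand for weaker inhibition and lower numbers for stronger inhibition), compound 3 gives "not determined" (no result reported), so no single number stands for it. Two related thioureas give the scale of the series: in this assay compound 1 `CC1(C)CC(NC(=S)Nc2cccc(Cl)c2)c2cc(Br)ccc2O1` gives 7000 nM, and in this assay compound 2 `CC1(C)CC(NC(=S)Nc2cccc(C#N)c2)c2cc(Cl)ccc2O1` gives 6000 nM; those two values lie within the scatter of each other. Compound 4 `CC1(C)CC(NC(=O)Nc2cccc(Cl)c2)c2cc(Cl)ccc2O1` differs from compound 3 in one place: chloro in place of hydrogen on an aromatic carbon. Among the compounds with values here, with no measured step to anchor it, the change from compound 3 to compound 4 is expected to produce at most a shift within the scatter in this assay, in no settled direction. Compound 4 is therefore estimated to give 8000 nM in this assay, within a range from 2000 nM to 40000 nM.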

Compound 4, half-maximal inhibitory concentration: 25000 nM
Compound 4: middle estimate off by 3.1-fold (0.49 log units), on the low side; measured number inside the range.
By their numbers in this assay, from the lowest: compounds 2 and 1 (each within the scatter of the next); then compound 4.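

Within the data shown here, compound 3 has no single number, so no step to compound 4 can be read. The compounds shown leave open what chloro in place of hydrogen does to inhibition here. Nothing at hand accounts for the value of compound 4.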